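Swapping the Amide Arm for a Methoxyphenyl Ring

The compounds below may be only part of what the source reports. "The series", "measured", "known", "first", "only" and "open" are said of these compounds alone.

Compound 1, `CCOC(=O)C1=Cc2ccccc2OC1(OCc1cn(-c2ccc(C)cc2)nn1)C(F)(F)F`: 26700 nM
Compound 2, `CCOC(=O)C1=Cc2ccccc2OC1(OCc1cn(CC(=O)NC2CCCCC2)nn1)C(F)(F)F`: 12100 nM
Compound 3, `CCOC(=O)C1=Cc2ccccc2OC1(OCc1cn(CC(=O)Nc2cccc(Cl)c2)nn1)C(F)(F)F`: 11600 nM

Three compounds sharing one core were tested in a functional assay on MCF7 cells (Homo sapiens) for inhibition, read by MTT assay, with a stated time of 24 h; a higher number here means a weaker inhibitor, a lower number a stronger inhibitor. Compound 3 gives the lowest number of the three, but compound 2 at 12100 nM lies within the scatter of it; only compound 1 stands apart, by a 2.3-fold lower number from compound 1 to compound 3 (0.36 log units; beyond the scatter).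

Compound 4, `CCOC(=O)C1=Cc2ccccc2OC1(OCc1cn(-c2cccc(OC)c2)nn1)C(F)(F)F`, differs from compound 3 in one place: 3-methoxyphenyl in place of ((3-chlorophenyl)carbamoyl)methyl on an aromatic nitrogen. The relevant measured steps run the other way: a 2.2-fold lower number from compound 1 to compound 2 (0.34 log units; beyond the scatter) and a 2.3-fold lower number from compound 1 to compound 3 (0.36 log units; beyond the scatter), both modest, both lowering the number when the aryl group on that nitrogen gave way to a carbamoylmethyl arm. Restoring an aryl group should reverse that. Compound 4 is therefore expected to show a modest rise, a 2.1-fold higher number from compound 3 to compound 4 (0.32 log units; beyond the scatter). Compound 4 is estimated at 24000 nM in this assay, with a range from 10000 nM to 55000 nM.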

Compound 4, half-maximal inhibitory concentration: > 150000 nM
Compound 4 gave a limit, no number; the forecaster's own chance of this, stated with the estimate: 10%; at least 6.2-fold (0.79 log units) between middle value and limit.
By their numbers in this assay, from the lowest: compounds 3 and 2 (each within the scatter of the next); then compound 1. At a limit, above all of these: compound 4.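

Compound 4 gives > 150000 nM in this assay, which is a limit and not a number. Returning to an aryl group on this nitrogen can therefore cost far more than the earlier steps showed, with an at least 12-fold higher number from compound 3 to compound 4 (1.11 log units; beyond the scatter) and an at least 12-fold higher number from compound 2 to compound 4 (1.09 log units; beyond the scatter). Nor are the two aryl groups interchangeable here, since 3-methoxyphenyl in place of 4-methylphenyl gives an at least 5.6-fold higher number from compound 1 to compound 4 (0.74 log units; beyond the scatter).

The limit leaves the full size of these steps open. On these data alone, it also remains open whether a phenyl ring carrying an amine or a carboxylic acid would stay near compound 1 or fall with compound 4.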